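A few compounds are considered here, and "the series" means these few. Any claim that something is new, unique, unknown or untested is made for them only; others in the source may bear on it.

Compound 1, `COC(=O)c1ccc(OCCCCOc2ccc(C(=O)CC3CCCC3)c(O)c2C)cc1`: in an assay on HEK293 cells for positive allosteric modulation of metabotropic glutamate receptor 3 (Rattus norvegicus), read by thallium flux, with a stated time of 2.5 min (on this read-out lower numbers stand for smaller maximal responses and higher numbers for larger maximal responses), compound 1 gives 22%.
Compound 2, `COC(=O)c1ccc(OCCCCOc2ccc(C(=O)CC(C)C)c(O)c2C)cc1`: in this assay compound 2 gives 22.7%.
Compound 3, `Cc1c(OCCCCOc2ccccc2C(=O)O)ccc(C(=O)CC(C)C)c1O`: not yet measured.

Of the two numbers, compound 2 stands nearest to compound 1, and the step of a number 0.7 percentage points higher from compound 1 to compound 2 (within the scatter) shows the two within the scatter. Compound 3 differs from compound 2 by 2-carboxyphenyl in place of 4-(methoxycarbonyl)phenyl on an oxygen on a saturated carbon. Within the data shown here, the single measured step concerns a different part of the molecule and lies within the scatter, so no measured step bears on this change. No movement beyond the scatter in this assay is therefore expected, with a wide range. Compound 3 is estimated at 22%, between 5% and 45%. This estimate expects a step of a number 0.7 percentage points lower from compound 2 to compound 3 (within the scatter).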

Compound 3, largest response reached (reported as percent of maximum), in percent of the reference or control that the assay uses: 28.1%
Beside the measured number, compound 3's estimate is 6.1 percentage points below it, and the stated range covers the measured number.
By their numbers in this assay, from the lowest: compounds 1, 2 and 3 (each within the scatter of the next).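

In this assay, 2-carboxyphenyl in place of 4-(methoxycarbonyl)phenyl on an oxygen on a saturated carbon gives a number 5.4 percentage points higher from compound 2 to compound 3 (within the scatter), so this exchange, which brings in a hydrogen-bond donor, leaves the maximal response within the scatter. Among these compounds, the earlier step concerned only the group on a saturated chain carbon bound to a carbonyl carbon, so this is the first reading at this place. No measurement at hand accounts for the result.

Going by these compounds, the step changes the group's identity and its substitution together, so it remains open how 4-carboxyphenyl or 2-(methoxycarbonyl)phenyl would compare. On these data alone, whether a primary amide on that phenyl ring would behave alike also remains open.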